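The source may report more compounds than this note shows. Statements on the series, on what has been measured and on what is new or still open speak of the compounds shown alone.

Compound 1 (`C[C@H](NC(=O)/C(C#N)=C/c1cccc(Br)n1)c1ccc(Br)cc1`): 1800 nM
Compound 2 (`CC[C@H](NC(=O)/C(C#N)=C/c1cccc(Br)n1)c1ccccc1`): 1400 nM

In a functional assay on U-266 cells (Homo sapiens) for antiproliferative activity, read by MTT assay, with a stated time of 72 h (a lower number here means a stronger inhibitor, a higher number a weaker inhibitor), compound 2 gives 1400 nM and compound 1 gives 1800 nM, a gap within the usual scatter, so the two cannot be ranked. Compound 3 (`CC(=O)OC[C@H](NC(=O)/C(C#N)=C/c1cccc(Br)n1)c1ccccc1`) carries acetoxy in place of methyl on a saturated chain carbon, two bonds along the chain from an amide-type nitrogen and an aromatic carbon. Among the measured compounds shown here, no measured pair shows what a change at this carbon does, so only a small rise in the number is expected in this assay, hardly beyond the scatter (a 1.4-fold higher number from compound 2 to compound 3 (0.15 log units; within the scatter)). Compound 3 is estimated at 2000 nM (expected range 700 nM to 6000 nM).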

Compound 3, half-maximal inhibitory concentration: 2800 nM
The estimate for compound 3 lay 1.4-fold (0.15 log units) below the measured number; the measured number falls inside the stated range.
By their numbers in this assay, from the lowest: compounds 2, 1 and 3 (each within the scatter of the next).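

In this assay, putting acetoxy in place of methyl on this saturated chain carbon gives a 2.0-fold higher number from compound 2 to compound 3 (0.30 log units; within the scatter). Among the compounds shown here, this is the first measured change at this carbon, and even with 4 heavy atoms and 2 hydrogen-bond acceptors entering, the shift does not clear the scatter, so no real loss can be claimed. No measurement on hand accounts for the result. As far as these compounds go, whether a hydroxyl, an amine or a carboxylic acid at this carbon would also stay within the scatter remains open.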